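The source may hold more compounds than are shown below. What is called first, only, known or untested is meant among the compounds shown, and "the series" means these compounds.

Working notes on the series. Compound 1 `Cc1ccc(S(=O)(=O)Nc2cccc(/C=C/C(=O)C[C@@H]3OC[C@@H](O)[C@H](O)[C@H]3O)c2)cc1` in an ADME assay on Vero cells (Chlorocebus sabaeus) for cytotoxicity, read by resazurin assay, with a stated time of 2 days (on this read-out higher numbers stand for lower toxicity in this test and lower numbers for higher toxicity in this test), gives 94700 nM. Compound 2 `O=C(/C=C/c1cccc(NC(=O)Nc2ccccc2)c1)C[C@@H]1OC[C@@H](O)[C@H](O)[C@H]1O` differs from compound 1 in its core by phenylcarbamoyl in place of (4-methylphenyl)sulfonyl on a nitrogen on an aromatic ring; in this assay compound 2 gives 309000 nM, a step of a 3.3-fold higher number from compound 1 to compound 2 (0.51 log units; beyond the scatter). Compound 3 `CCOC(=O)/C=C/c1cccc(NS(=O)(=O)c2ccc(C)cc2)c1` carries the change (ethoxy in place of (3,4,5-trihydroxyoxan-2-yl)methyl on a carbonyl carbon); in this assay compound 3 gives 77100 nM, a step of a 1.2-fold lower number from compound 1 to compound 3 (0.09 log units; within the scatter). Compound 4 `CCOC(=O)/C=C/c1cccc(NC(=O)Nc2ccccc2)c1` is not yet measured; it carries the same change relative to compound 2, namely (ethoxy in place of (3,4,5-trihydroxyoxan-2-yl)methyl on a carbonyl carbon), at a place described in the same words. Because the identical change once gave a 1.2-fold lower number from compound 1 to compound 3 (0.09 log units; within the scatter), the step to compound 4 is expected to be of similar size, a 1.1-fold lower number from compound 2 to compound 4 (0.06 log units; within the scatter), resting on that single pair alone. Compound 4 is therefore estimated at 270000 nM, with an expected range from 140000 nM to 520000 nM.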

Compound 4, half-maximal cytotoxic concentration: 293000 nM
Compound 4: middle estimate off by 1.1-fold (0.04 log units), on the low side, within the range that was stated.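

In this assay, ethoxy in place of (3,4,5-trihydroxyoxan-2-yl)methyl on the carbonyl carbon gives a 1.1-fold lower number from compound 2 to compound 4 (0.02 log units; within the scatter), and the earlier pair sets the size of this step on a second core: the same change on two cores in this assay, a 1.2-fold lower number (0.09 log units; within the scatter) from compound 1 to compound 3 and a 1.1-fold lower number (0.02 log units; within the scatter) from compound 2 to compound 4, 1.2-fold (0.07 log units) apart, within the scatter of two such steps. On these two cores the change therefore carries over without a difference that can be told from the scatter, and on neither does it move the number beyond the scatter. Two pairs do not show that this holds on other cores, and they show nothing about any other read-out.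

The compounds shown leave open whether an amine or a longer chain in place of ethoxy on the carbonyl carbon would leave the number equally unmoved.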